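This account rests on a few compounds, and the source may have more. Where it says the series, first, only, none or still open, it means among the compounds named here.

Compound 3 `Cc1nc2c3ccccc3ccc2c2nc3c(ccc4ccccc43)c(-c3ccccc3S)c12` gives 89 ug/mL in a functional assay, read by spectrophotometry, with a stated time of 30 min; on this read-out lower numbers stand for stronger inhibition and higher numbers for weaker inhibition. Among the three compounds measured so far it holds the second highest number: compound 2 `Cc1nc2c3ccccc3ccc2c2nc3c(ccc4ccccc43)c(-c3nccnc3N)c12` gives 81.7 ug/mL and compound 1 `Cc1nc2c3ccccc3ccc2c2nc3c(ccc4ccccc43)c(-c3cccnc3)c12` gives 98.2 ug/mL, and both of these stand within the scatter of compound 3. Compound 4 `Cc1nc2c3ccccc3ccc2c2nc3c(ccc4ccccc43)c(-c3ccc(O)cc3)c12` has not yet been measured. The change from compound 3 to compound 4 is 4-hydroxyphenyl in place of 2-sulfanylphenyl on an aromatic carbon. Going by the values given here, two measured steps bear on it, since each also exchanges the group on that same aromatic carbon: a 1.1-fold lower number from compound 1 to compound 3 (0.04 log units; within the scatter) and a 1.1-fold higher number from compound 2 to compound 3 (0.04 log units; within the scatter). The remaining step, a 1.2-fold lower number from compound 1 to compound 2 (0.08 log units; within the scatter), likewise exchanges the group at that place without moving the number beyond the scatter. On this basis no step beyond the scatter is expected from compound 3 to compound 4 in this assay, which would mean a 1.0-fold lower number from compound 3 to compound 4 (0.02 log units; within the scatter). Compound 4 is therefore expected to give about 85 ug/mL in this assay, with a range from 45 ug/mL to 170 ug/mL.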

Compound 4, half-maximal inhibitory concentration: 86.4 ug/mL
Estimate against measurement, compound 4: 1.0-fold (0.01 log units) below; measured number inside the range.
By their numbers in this assay, from the lowest: compounds 2, 4, 3 and 1 (each within the scatter of the next).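

In this assay the exchange of 2-sulfanylphenyl for 4-hydroxyphenyl on this aromatic carbon, opposite the ring nitrogen, stays within the scatter (a 1.0-fold lower number from compound 3 to compound 4 (0.01 log units; within the scatter)). The new group also stays within the scatter of the two other groups at this place (a 1.1-fold higher number from compound 2 to compound 4 (0.02 log units; within the scatter); a 1.1-fold lower number from compound 1 to compound 4 (0.06 log units; within the scatter)), so the four groups now compared, which include a second carbon-only aromatic ring carrying a different substituent, give numbers that cannot be told apart. Nothing available here offers an explanation for this result.

Still open, on these data alone, is whether a group of another kind on this carbon, such as a carboxylic acid, an amine on a longer chain or a plain hydrogen, would take the number beyond the scatter. The compounds shown also leave open whether a change elsewhere on the shared core would do so.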